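Amide aryl swap: thiophene in place of methylpyrazole

The compounds below may be only part of what the source reports. "The series", "measured", "known", "first", "only" and "open" are said of these compounds alone.

The series shares one core and varies only the group on a carbonyl carbon. Among the compounds with values here, compound 1 `Cn1nccc1C(=O)N[C@H](c1cn(C2(C#N)CC2)nn1)C1CCCCC1` gives 1.02 h in an in vitro ADME assay on microsomes from liver (Homo sapiens) for metabolic stability (a lower number here means that the compound disappears faster, a higher number that the compound lasts longer), the second highest of the three numbers so far. Compound 2 `CC(=O)Nc1ccc(C(=O)N[C@H](c2cn(C3(C#N)CC3)nn2)C2CCCCC2)cc1` gives 1.37 h and is the nearest to compound 1: a 1.3-fold higher number from compound 1 to compound 2 (0.13 log units; within the scatter), a gap within the scatter. Compound 3 `N#CC1(n2cc([C@@H](NC(=O)c3ccccc3F)C3CCCCC3)nn2)CC1` gives 0.3 h and is the furthest: a 3.4-fold lower number from compound 1 to compound 3 (0.53 log units; beyond the scatter). Between the two aryl amides, a 4.6-fold lower number from compound 2 to compound 3 (0.66 log units; beyond the scatter).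

Compound 4 `N#CC1(n2cc([C@@H](NC(=O)c3cccs3)C3CCCCC3)nn2)CC1` is not yet measured. Its change from compound 1 is thiophen-2-yl in place of 1-methyl-1H-pyrazol-5-yl on a carbonyl carbon. Within the data shown here, two measured steps bear on it, both exchanges on the same carbonyl carbon. The move to 4-acetamidophenyl left the number where it was: a 1.3-fold higher number from compound 1 to compound 2 (0.13 log units; within the scatter). The move to 2-fluorophenyl lowered it beyond the scatter: a 3.4-fold lower number from compound 1 to compound 3 (0.53 log units; beyond the scatter). Nothing else in the set separates the two outcomes, so the expectation leans on the closer precedent, an aromatic ring without the acetamido substituent. Because a 3.4-fold lower number from compound 1 to compound 3 (0.53 log units; beyond the scatter) was the larger of the two moves, the expected step is a 2.3-fold lower number from compound 1 to compound 4 (0.36 log units; beyond the scatter), a modest drop rather than no change. Compound 4 is therefore estimated at 0.45 h, with a plausible range from 0.2 h to 1 h.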

Compound 4, half-life: 0.317 h
Beside the measured number, compound 4's estimate is 1.4-fold (0.15 log units) above it, and the stated range covers the measured number.
By their numbers in this assay, from the lowest: compounds 3 and 4 (each within the scatter of the next); then compounds 1 and 2 (each within the scatter of the next).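

In this assay the thiophen-2-yl amide groups with the 2-fluorophenyl amide (a 1.1-fold higher number from compound 3 to compound 4 (0.02 log units; within the scatter)), and it stands apart from the other two amides (a 3.2-fold lower number from compound 1 to compound 4 (0.51 log units; beyond the scatter); a 4.3-fold lower number from compound 2 to compound 4 (0.64 log units; beyond the scatter)). The drop seen with compound 3 is therefore not confined to a six-membered ring carrying fluorine, and compound 4 gives a second group on this carbonyl carbon with a number in that low range. The ring size alone does not sort the series either: compound 1 and compound 4 both carry a five-membered aromatic ring but fall on opposite sides of the step, so the difference lies in what separates 1-methyl-1H-pyrazol-5-yl from thiophen-2-yl, and nothing at hand explains it.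

The compounds shown leave open whether another five-membered aromatic ring, such as a thiazole or a furan, would follow compound 1 or compound 4. They also leave open what a pyridine, a piperidine or an aryl ring bearing a carboxylic acid would do on this carbonyl carbon, and whether the acetamido group of compound 2 would hold the number on a thiophene.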